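The compounds below may be only part of what the source reports. "The series", "measured", "known", "first", "only" and "open" are said of these compounds alone.

Compound 2 `CC(=O)OCCOCN1c2ccccc2C(=O)N(Cc2ccccc2)S1(=O)=O` and compound 3 `C#CCOCN1c2ccccc2C(=O)N(Cc2ccccc2)S1(=O)=O` share one core. In a functional assay on CCRF-CEM cells (Homo sapiens) for cytotoxicity (a higher number here means that more compound is tolerated, a lower number that less compound is tolerated), compound 2 gives 103 ug/mL, and compound 3 gives 23 ug/mL. The change between them is ethynyl in place of acetoxymethyl on a saturated chain carbon bound to an oxygen on a saturated carbon, and it moved the read-out by a 4.5-fold lower number from compound 2 to compound 3 (0.65 log units; beyond the scatter). Compound 1 `CC(=O)OCCOCN1C(=O)c2ccccc2NS1(=O)=O` carries a different core; the difference between the two cores is not broken down here. In this assay compound 1 gives > 200 ug/mL, which is a limit of the assay the limit of > 200 ug/mL in this assay, at which 1 of the 3 values shown sits, rather than a number. Compound 4 `C#CCOCN1C(=O)c2ccccc2NS1(=O)=O` differs from compound 1 by ethynyl in place of acetoxymethyl on a saturated chain carbon bound to an oxygen on a saturated carbon, the same change at the same place. Because compound 1 sits at the limit of > 200 ug/mL in this assay, at which 1 of the 3 values shown sits, the starting point is open, so only a downward move of about the size seen in a 4.5-fold lower number from compound 2 to compound 3 (0.65 log units; beyond the scatter) can be expected, from an unknown height. Compound 4 is estimated at 80 ug/mL, with a range from 30 ug/mL to 250 ug/mL. The step of an at least 2.5-fold lower number from compound 1 to compound 4 (0.39 log units; beyond the scatter) is expected to resemble the earlier one.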

Compound 4, half-maximal cytotoxic concentration: > 200 ug/mL
Compound 4: a limit, no number; the forecaster's own chance of this, stated with the estimate: 30%; at least 2.5-fold (0.39 log units) between middle value and limit.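

Compound 1 and compound 4 both stand at a limit, not a number, so no step between them can be read in this assay: the limit of > 200 ug/mL in this assay, at which 2 of the 4 values shown sit.

Going by these compounds, how far ethynyl in place of acetoxymethyl moves the read-out on the core of compound 1 stays open.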